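Bromo to dimethylaminophenyl: expected kinetic solubility

The source may report more compounds than this note shows. Statements on the series, on what has been measured and on what is new or still open speak of the compounds shown alone.

Compound 1 `Cc1cc(NCc2ccccn2)n2ncc(-c3ccc(F)cc3)c2n1` gives in a physicochemical assay for solubility, read by HPLC, using the shake flask method, measured as kinetic solubility, with a stated time of 2 h, at pH 7.4 (a lower number here means a less soluble compound, a higher number a more soluble compound), a value that is a limit of the assay, < 5000 nM.
Compound 2 `Cc1cc(NCc2ccccn2)n2ncc(Br)c2n1` gives in this assay 89300 nM.

For the measured compounds named here, compound 2 holds the only actual number in this assay; the other value shown for this series is a limit (the limit of < 5000 nM in this assay, at which 1 of the 2 values shown sits), so compound 2 stands as the one compound with a measured solubility. Compound 3 `Cc1cc(NCc2ccccn2)n2ncc(-c3ccc(N(C)C)cc3)c2n1` differs from it by 4-(dimethylamino)phenyl in place of bromo on an aromatic carbon. Going by the values given here, the one measured step that bears on this change runs the other way: an at least 17-fold higher number from compound 1 to compound 2 (1.25 log units; beyond the scatter), where an aryl group at this carbon was replaced by bromo. Putting an aryl group back in its place is therefore expected to lower the number again, with the step of an 11-fold lower number from compound 2 to compound 3 (1.05 log units; beyond the scatter) as the estimate. Compound 3 is accordingly expected to give about 8000 nM in this assay, within a range from 2000 nM to 40000 nM, and it may come out as a limit rather than a number.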

Compound 3, solubility: < 5000 nM
Compound 3 gave a limit, no number (the forecaster's own chance of this, stated with the estimate: 35%); middle value at least 1.6-fold (0.20 log units) away from the limit.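

Replacing bromo with 4-(dimethylamino)phenyl gives an at least 17-fold lower number from compound 2 to compound 3 (1.25 log units; beyond the scatter), so the large drop is not confined to the 4-fluorophenyl group of compound 1 but recurs with a second aryl group on this aromatic carbon. In this assay compound 3 also ends at a limit, as compound 1 does, so dimethylamino in place of fluoro on the phenyl ring does not yield a measured number. The step between these two compounds cannot be read, since both ends are limits: the limit of < 5000 nM in this assay, at which 2 of the 3 values shown sit.

From the compounds shown here alone, how far compound 1 and compound 3 lie past that limit remains open. Also open, going by these compounds, is whether a phenyl ring carrying a carboxylic acid, or a morpholine set directly on this carbon instead of an aryl group, would return a measured number.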